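A few compounds are considered here, and "the series" means these few. Any claim that something is new, unique, unknown or untested is made for them only; others in the source may bear on it.

The measured compounds, all in a functional assay, with a stated time of 30 min; on this read-out lower numbers stand for stronger inhibition and higher numbers for weaker inhibition:

Compound 1, `O=C(/C=C/c1ccccc1O)CC(=O)/C=C/c1cccc(O)c1O`: compound 1 gives 23000 nM.
Compound 2, `O=C(/C=C/c1cccc(O)c1)CC(=O)/C=C/c1cccc(O)c1O`: compound 2 gives 29000 nM.
Compound 3, `O=C(/C=C/c1ccccc1O)CC(=O)c1ccc(O)c(O)c1`: compound 3 gives 16000 nM.

Compound 1 and compound 2 share a core and differ in one place: 3-hydroxyphenyl in place of 2-hydroxyphenyl on a double-bonded chain carbon bound to a double-bonded chain carbon. This change made a step of a 1.3-fold higher number from compound 1 to compound 2 (0.10 log units; within the scatter), so the two values sit within the usual scatter of each other and do not separate.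

Compound 3 carries a different core. How it differs from compound 1 is not broken down here. Its value and those of compound 1 and compound 2 all fall within the scatter of one another, so none of the three can be set above or below the others.

Compound 4, `O=C(/C=C/c1cccc(O)c1)CC(=O)c1ccc(O)c(O)c1`, has not yet been measured. It stands to compound 3 as compound 2 stands to compound 1: 3-hydroxyphenyl in place of 2-hydroxyphenyl on a double-bonded chain carbon bound to a double-bonded chain carbon. The place of the change is described in the same words for both pairs, so this is the same change made on the core of compound 3.

Because the earlier step of a 1.3-fold higher number from compound 1 to compound 2 (0.10 log units; within the scatter) stayed within the scatter, the step from compound 3 to compound 4 is expected to be of similar size, a 1.3-fold higher number from compound 3 to compound 4 (0.10 log units; within the scatter), and this rests on that single precedent alone. Compound 4 is therefore estimated at 20000 nM in this assay, with a likely range from 9000 nM to 45000 nM.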

Compound 4, half-maximal inhibitory concentration: 10000 nM
Compound 4: the middle estimate sits 2.0-fold (0.30 log units) above what was measured; measured number inside the range.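

In this assay, setting 3-hydroxyphenyl in place of 2-hydroxyphenyl on the core of compound 3 gives a 1.6-fold lower number from compound 3 to compound 4 (0.20 log units; within the scatter), so this pair does not separate, just as the pair on the core of compound 1 did not. Set side by side, the two steps do not differ, and the opposite directions they print carry no weight: the same change on two cores in this assay, a 1.3-fold higher number (0.10 log units; within the scatter) from compound 1 to compound 2 and a 1.6-fold lower number (0.20 log units; within the scatter) from compound 3 to compound 4, 2.0-fold (0.30 log units) apart, within the scatter of two such steps. For the compounds shown here, this shows that on these two cores the change leaves the number within the usual scatter and that it carried from one core to the other without a difference that can be detected, but it rests on only two pairs and does not show that the change is without consequence on any other core, nor that the two hydroxyphenyl groups are equivalent outside this assay.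

The compounds shown leave open whether any group at this place would move the number beyond the scatter, since only 2-hydroxyphenyl and 3-hydroxyphenyl appear there. A 4-hydroxyphenyl, a methoxyphenyl or a phenyl ring bearing an amine or a carboxylic acid at that place, or a longer chain joining the two carbonyl groups, remains untested in what is shown here.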